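The compounds below may be only part of what the source reports. "The series", "measured", "known", "first", "only" and "open" are said of these compounds alone.

Measured compounds in a functional assay on MDA-MB-435 cells (Homo sapiens) for inhibition, read by sulforhodamine B assay, with a stated time of 48 h; on this read-out lower numbers stand for stronger inhibition of growth and higher numbers for weaker inhibition of growth:
- compound 1 `COc1cc2cc(Oc3ccc(NC(=O)Nc4cccc(C(F)(F)F)c4)cc3)c(C)nc2cc1OC`: 1630 nM
- compound 2 `COc1cc2cc(Oc3ccc(NC(=O)Nc4ccc(Cl)c(C(F)(F)F)c4)cc3)c(C)nc2cc1OC`: 1030 nM

Compound 1 and compound 2 share the same core and differ only on the outer aryl ring of the urea. The one measured step, a 1.6-fold lower number from compound 1 to compound 2 (0.20 log units; within the scatter), is within the scatter; compound 2 therefore stands at the lower end of the two numbers shown without being separated from compound 1 in this assay.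

Compound 3 `COc1cc2cc(Oc3ccc(NC(=O)Nc4ccc(Cl)c(Cl)c4)cc3)c(C)nc2cc1OC` is the next member. The change from compound 2 is chloro in place of trifluoromethyl on an aromatic carbon. Within the data shown here, no measured step covers a trifluoromethyl giving way to a chloro; the only step available, a 1.6-fold lower number from compound 1 to compound 2 (0.20 log units; within the scatter), concerns a chloro entering in place of hydrogen at another position and did not move beyond the scatter. The data therefore give no ground to expect a step beyond the scatter in this assay in either direction for compound 3.

Compound 3 is estimated at 1200 nM in this assay, within a range of 500 nM to 3000 nM, which is expected to amount to a 1.2-fold higher number from compound 2 to compound 3 (0.07 log units; within the scatter).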

Compound 3, concentration for 50% growth inhibition: 3090 nM
The estimate for compound 3 lay 2.6-fold (0.41 log units) below the measured number; measured number outside the range, above it.
By their numbers in this assay, from the lowest: compounds 2, 1 and 3 (each within the scatter of the next, the first and the last beyond it).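

In this assay, among these compounds, the place held by trifluoromethyl on the 4-chloro-3-(trifluoromethyl)phenyl group is the first where a single change moves the number beyond the scatter (a 3.0-fold higher number from compound 2 to compound 3 (0.48 log units; beyond the scatter)), with chloro entering in place of trifluoromethyl. This separation holds only against compound 2, since the step to 3,4-dichlorophenyl from 3-(trifluoromethyl)phenyl on the amide-type nitrogen stays within the scatter (a 1.9-fold higher number from compound 1 to compound 3 (0.28 log units; within the scatter)), so compound 3 is not set apart from compound 1. The data at hand offer nothing that accounts for the step from trifluoromethyl to chloro.

Going by these compounds, how a nitrile, a methoxy or a dimethylamine at this same place would read in this assay, and whether any of them would fall with compound 2 or with compound 3, stays open. Also open, on these data alone, is whether the step from trifluoromethyl to chloro would keep its size with a thiourea in place of the urea, or with a morpholine attached to the shared core.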